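The source may hold more compounds than are shown below. What is called first, only, known or untested is meant among the compounds shown, and "the series" means these compounds.

Compound 2 `COc1cc2cc(Oc3ccc(NC(=O)Nc4cccc(C(F)(F)F)c4)cc3)c(C)nc2cc1OC` and compound 1 `COc1cc2cc(Oc3ccc(NC(=O)Nc4ccc(C)cc4)cc3)c(C)nc2cc1OC` share one core and differ only in the aryl group on the urea nitrogen. In a functional assay on 786-0 cells (Homo sapiens) for inhibition, read by sulforhodamine B assay, with a stated time of 48 h, tested at 10 uM (on this read-out higher numbers stand for a weaker effect at the one concentration tested and lower numbers for a stronger effect), compound 1 gives 126%, while compound 2 gives 15.1%; the step of a number 110.9 percentage points lower from compound 1 to compound 2 (beyond the scatter) is the only one measured here, and it leaves compound 2 with the lowest of the two numbers, the nearest being compound 1, far above it.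

Compound 3 `COc1cc2cc(Oc3ccc(NC(=O)Nc4ccc(Cl)c(C(F)(F)F)c4)cc3)c(C)nc2cc1OC` is built from compound 2 by a single change: chloro in place of hydrogen on an aromatic carbon. Going by the values given here, no measured step matches this change; the step from compound 1 to compound 2 swapped the whole aryl group and says nothing direct about adding chloro. The starting number of compound 2 is already low, so only a small further drop, or none beyond the scatter, is expected, with a number 5.1 percentage points lower from compound 2 to compound 3 (within the scatter) as the estimated step. Compound 3 is therefore expected to give 10%, in the range from 2% to 30%.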

Compound 3, a percentage reported as activity, at one concentration (the size of the read-out at that concentration, not a potency): -21.1%
Estimate against measurement, compound 3: 31.1 percentage points above; the measured number lies below the stated range.
By their numbers in this assay, from the lowest: compound 3; then compound 2; then compound 1.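

In this assay, one chloro on the aromatic carbon ortho to the trifluoromethyl group and para to a large group gives a number 36.2 percentage points lower from compound 2 to compound 3 (beyond the scatter), so this position still responds to a small change even though compound 2 already had a low number. Taken as one swap of the whole aryl group, 4-chloro-3-(trifluoromethyl)phenyl in place of 4-methylphenyl gives a number 147.1 percentage points lower from compound 1 to compound 3 (beyond the scatter). Nothing available here bears on the reason for this drop.

The compounds shown leave open whether chloro is special at this place, or whether a bromo, a methyl or an amine there would give a similar number. They also leave open whether chloro would have the same effect on an aryl group without the trifluoromethyl group.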